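This account rests on a few compounds, and the source may have more. Where it says the series, first, only, none or still open, it means among the compounds named here.

Working notes on the series. The compounds share a 2-hydroxyphenyl group on a common core. Compound 1 `Cn1ccnc1Sc1cnc(-c2ccc(Cl)cc2)nc1-c1ccccc1O` has been tested in an ADME assay on MDCK cells (Canis lupus familiaris) for cytotoxicity (a higher number here means that more compound is tolerated, a lower number that less compound is tolerated), where compound 1 gives 80100 ug/mL. Compound 2 `CC(C)(C)c1nccc(-c2ccccc2O)n1` in this assay gives 16300 ug/mL. Compound 1 thus stands highest of the two numbers; the nearest, compound 2, shows a lower number, and the gap between the two values lies beyond the usual scatter. For the measured compounds named here, no single-point step between these two compounds has been worked out, as their structures differ in more than one place.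

Compound 3 `Cn1ccnc1Sc1cnc(N)nc1-c1ccccc1O` has not yet been measured in this assay. It differs from compound 1 by amino in place of 4-chlorophenyl on an aromatic carbon; the amino group enters between two ring nitrogen atoms, meta to a 2-hydroxyphenyl group and para to a (1-methyl-1H-imidazol-2-yl)sulfanyl group, on the shared core. Nothing measured in the series shows how a change of this kind moves the number in this assay. The step of a 1.2-fold higher number from compound 1 to compound 3 (0.10 log units; within the scatter) that is expected is small and upward, if beyond the scatter at all. Compound 3 is therefore estimated to give 100000 ug/mL in this assay, with a range from 40000 ug/mL to 250000 ug/mL.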

Compound 3, half-maximal cytotoxic concentration: 388000 ug/mL
The estimate for compound 3 lay 3.9-fold (0.59 log units) below the measured number, and the stated range ends below it.
By their numbers in this assay, from the lowest: compound 2; then compound 1; then compound 3.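

In this assay, amino in place of 4-chlorophenyl on an aromatic carbon, at the place between two ring nitrogen atoms, gives a 4.8-fold higher number from compound 1 to compound 3 (0.69 log units; beyond the scatter) on the shared core, which shows that the group at this position can move the number beyond the scatter. The step also shows that the number does not depend on keeping 4-chlorophenyl here: the group of 7 heavy atoms can give way to one of 1 heavy atom, and the number still rises. Nothing at hand accounts for the step, and it stands as an observation on this single pair.

The compounds shown leave open whether the rise follows from the amino group itself or from the loss of 4-chlorophenyl; a methyl group, a dimethylamino group or a plain hydrogen at this position would help to separate the two. They also leave open whether the same change gives a similar step when a simple amine chain or a carboxylic acid stands in place of the (1-methyl-1H-imidazol-2-yl)sulfanyl group.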